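Hydrazone aryl replacement: nitrooxyphenyl in place of hydroxyphenyl

The compounds below may be only part of what the source reports. "The series", "measured", "known", "first", "only" and "open" are said of these compounds alone.

Two members of the series carry a measurement in a functional assay on A549 cells (Homo sapiens) for cytotoxicity, read by MTT assay, with a stated time of 72 h; on this read-out higher numbers stand for weaker inhibition and lower numbers for stronger inhibition. Compound 1 `CN(C)CCn1cnnc1-c1cc(Oc2ccc(NC(=O)N/N=C/c3ccc(F)cc3Cl)cc2F)ccn1` gives 1120 nM in this assay, and compound 2 `CN(C)CCn1cnnc1-c1cc(Oc2ccc(NC(=O)N/N=C/c3ccc(O)cc3)cc2F)ccn1` gives 3560 nM. Compound 2 therefore stands highest of the two numbers, its nearest neighbour being compound 1; the step between them, a 3.2-fold higher number from compound 1 to compound 2 (0.50 log units; beyond the scatter), came with 4-hydroxyphenyl in place of 2-chloro-4-fluorophenyl on a carbon with a double bond to nitrogen.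

Compound 3 `CN(C)CCn1cnnc1-c1cc(Oc2ccc(NC(=O)N/N=C/c3ccccc3O[N+](=O)[O-])cc2F)ccn1` is not yet measured. It differs from compound 2 by 2-(nitrooxy)phenyl in place of 4-hydroxyphenyl on a carbon with a double bond to nitrogen. For the measured compounds named here, the only step that bears on it is the one from compound 1 to compound 2, which shows that exchanging the aryl group on this carbon moved this assay by a modest amount. An exchange of comparable size is expected here, in the direction of a lower number, so that the step from compound 2 to compound 3 is estimated at a 2.0-fold lower number from compound 2 to compound 3 (0.30 log units; within the scatter). Compound 3 is thus expected to give about 1800 nM in this assay, within a range of 700 nM to 4500 nM.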

Compound 3, half-maximal inhibitory concentration: 1200 nM
Compound 3: the middle estimate sits 1.5-fold (0.18 log units) above what was measured; measured number inside the range.
By their numbers in this assay, from the lowest: compounds 1 and 3 (each within the scatter of the next); then compound 2.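

In this assay, 2-(nitrooxy)phenyl in place of 4-hydroxyphenyl on this carbon gives a 3.0-fold lower number from compound 2 to compound 3 (0.47 log units; beyond the scatter), a second aryl exchange beyond the scatter. Set against 2-chloro-4-fluorophenyl, the same group gives a 1.1-fold higher number from compound 1 to compound 3 (0.03 log units; within the scatter), so these two quite different aryl groups cannot be told apart here, and among the three shown only 4-hydroxyphenyl stands apart, with the higher number. No measurement at hand explains either step.

Open, on these data alone, is where a plain phenyl or an aminophenyl on this carbon would fall, which would show whether the hydroxyl costs activity or the nitrooxy and halogen substituents each add it. Also open, as far as these compounds go, is whether these aryl steps hold in other cell lines or with another chain in place of the dimethylaminoethyl group.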